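Shortening the phenoxy chain toward a phenoxyethyl side chain

The source may report more compounds than this note shows. Statements on the series, on what has been measured and on what is new or still open speak of the compounds shown alone.

Compound 1 `O=C(O)c1csc([C@H]2CC[C@@H]3[C@@H](CCCCCOc4ccccc4)[C@H](O)C[C@@H]3O2)n1` gives "not determined" (no result reported) in a functional assay on CHO cells for agonist activity at prostaglandin E2 receptor EP3 subtype (Homo sapiens), read by fluorescence and calcium flux (on this read-out lower numbers stand for an effect already at smaller amounts and higher numbers for an effect only at larger amounts of compound), so it gives no starting number. Two related compounds do. Compound 2 `O=C(O)c1csc([C@H]2CC[C@@H]3[C@@H](/C=C/COc4ccccc4)[C@H](O)C[C@@H]3O2)n1` carries an unsaturated linker to the phenoxy group and gives 7600 nM in this assay. Compound 3 `O=C(O)c1csc([C@H]2CC[C@@H]3[C@@H](COc4ccccc4)[C@H](O)C[C@@H]3O2)n1` carries the shortest linker and reaches only a limit of this assay, > 10000 nM, which is not a number; this limit is where (the limit of > 10000 nM in this assay, at which 1 of the 3 values shown sits). Compound 4 `O=C(O)c1csc([C@H]2CC[C@@H]3[C@@H](CCOc4ccccc4)[C@H](O)C[C@@H]3O2)n1` differs from compound 1 in this way: phenoxy in place of 3-phenoxypropyl on a saturated chain carbon, two bonds along the chain from a saturated ring carbon. Because compound 1 has no value, no step size from it can be given for this assay; what is expected rests on compound 2 and compound 3, both weak, with the shorter linker of compound 3 reaching the limit. Compound 4 sits between them in chain length, so weak activity is expected, and the estimate for compound 4 in this assay is 8000 nM, within a range from 3000 nM to 20000 nM, with a real chance that only a limit is reported.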

Compound 4, half-maximal effective concentration: 1400 nM
For compound 4 the middle estimate is 5.7-fold (0.76 log units) above the measured one, outside the stated range (below it).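

In this assay, the length of the side chain at this position clearly matters: with phenoxymethyl in place of phenoxy on a saturated chain carbon bound to a saturated ring carbon, the result is an at least 7.1-fold lower number from compound 3 to compound 4 (0.85 log units; beyond the scatter). Compound 3 stands at a limit of the assay, so the step has a lower bound but no exact size: the limit of > 10000 nM in this assay, at which 1 of the 4 values shown sits. Among the compounds shown here, compound 4 therefore shows what the earlier compounds could not, that a change in this linker alone can move the read-out beyond the usual scatter.

For the compounds shown here, compound 1 has no result, so no step from it can be read, and the effect of its long saturated chain stays unknown. Going by these compounds, whether a saturated phenoxypropyl chain, or an amine in place of the chain oxygen, would lower the number further also remains open.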